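The source may report more compounds than this note shows. Statements on the series, on what has been measured and on what is new or still open speak of the compounds shown alone.

Measured compounds: compound 1 `ClCc1ccc(Cn2cnc3c(Cl)ncnc32)cc1` at 1000 nM; compound 2 `ClCc1cccc(Cn2cnc3c(Cl)ncnc32)c1` at 1950 nM.

Both values come from a functional assay on LOX IMVI cells (Homo sapiens) for cytotoxicity, read by sulforhodamine B assay, with a stated time of 48 h; on this read-out higher numbers stand for weaker inhibition of growth and lower numbers for stronger inhibition of growth. Compound 1 and compound 2 lie within the usual scatter of each other, so neither is set apart on these two numbers.

Compound 3 `ClCc1ccc(Cn2cnc3c(Cl)nc(Cl)nc32)cc1` differs from compound 1 by chloro in place of hydrogen on an aromatic carbon. For the measured compounds named here, no measured pair shows this change, so there is nothing to anchor its size. The change is small and the two measured numbers give no reason to expect a move beyond the scatter. The estimate for compound 3 in this assay is 900 nM, with a range from 300 nM to 2700 nM; this corresponds to an expected step of a 1.1-fold lower number from compound 1 to compound 3 (0.05 log units; within the scatter).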

Compound 3, concentration for 50% growth inhibition: 2040 nM
Compound 3: middle estimate off by 2.3-fold (0.36 log units), on the low side; the measured number falls inside the stated range.
By their numbers in this assay, from the lowest: compounds 1, 2 and 3 (each within the scatter of the next, the first and the last beyond it).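

In this assay chloro in place of hydrogen on an aromatic carbon, between two ring nitrogen atoms, gives a 2.0-fold higher number from compound 1 to compound 3 (0.31 log units; beyond the scatter) as a modest step beyond the scatter. This position therefore registers a substitution, and here the added chloro gives weaker growth inhibition than the hydrogen of compound 1. Nothing available on these compounds accounts for the step.

Open, going by these compounds, is whether an amine or a methoxy group at this same position would shift the number in the same direction. Also open, on these data alone, is whether the same chloro change on compound 2 would give a step of similar size.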